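From sec-butyl to cyclopentyl on the ring nitrogen

The source may report more compounds than this note shows. Statements on the series, on what has been measured and on what is new or still open speak of the compounds shown alone.

In a functional assay on HeLa cells (Homo sapiens) for antiproliferative activity, read by CCK-8 assay, with a stated time of 72 h (a lower number here means a stronger inhibitor, a higher number a weaker inhibitor), compound 1 `CCC(C)n1cnc2c(NCc3ccc(C(=O)Nc4ccccc4N)cc3)nc(Cl)nc21` gives 3030 nM and holds the higher of two numbers, while compound 2 `Cc1ccc(Nc2nc(Cl)nc3c2ncn3Cc2ccc(C(=O)Nc3ccccc3N)cc2)cc1` gives 1050 nM which is lower by more than the scatter. Compound 3 `Nc1ccccc1NC(=O)c1ccc(Cn2cnc3c(Nc4ccc(-c5ccccn5)cc4)nc(Cl)nc32)cc1` shows > 20000 nM as a limit and not a number.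

Compound 4 `Nc1ccccc1NC(=O)c1ccc(CNc2nc(Cl)nc3c2ncn3C2CCCC2)cc1` carries cyclopentyl in place of sec-butyl on an aromatic nitrogen and is otherwise the same as compound 1. Among the measured compounds shown here, no measured step changes the group on that nitrogen, and compound 1 and compound 2 differ in more than one place. For the measured compounds named here, the one measured step that changes a single place is an at least 19-fold higher number from compound 2 to compound 3 (1.27 log units; beyond the scatter) and it is large, but it falls on an aromatic carbon, so it bears on this change only weakly. In this assay no step beyond the scatter is therefore expected, in either direction. The estimated step of a 1.2-fold lower number from compound 1 to compound 4 (0.08 log units; within the scatter) is correspondingly small. Compound 4 is expected near 2500 nM within an estimated range of 900 nM to 7000 nM as its likely span.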

Compound 4, half-maximal inhibitory concentration: 3020 nM
The estimate for compound 4 lay 1.2-fold (0.08 log units) below the measured number, within the range that was stated.
By their numbers in this assay, from the lowest: compound 2; then compounds 4 and 1 (each within the scatter of the next). At a limit, above all of these: compound 3.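

Replacing sec-butyl with cyclopentyl on the aromatic nitrogen gives, in this assay, a 1.0-fold lower number from compound 1 to compound 4 (0.00 log units; within the scatter), so at this position a five-membered ring of carbon only reads the same as an open group with no ring. Among the compounds shown here, this is the first measured step at this nitrogen, since the earlier compounds either differ in more than one place or change an aromatic carbon instead. Nothing measured here explains why the two groups read alike.

Both groups are made of carbon only, so the compounds shown leave open how a chain ending in an amine, a carboxylic acid or a longer chain would read on this nitrogen. They also leave open whether the same swap would read alike if the rest of the molecule were different.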